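The compounds below may be only part of what the source reports. "The series", "measured", "known", "first", "only" and "open" are said of these compounds alone.

In a functional assay on MCF7 cells (Homo sapiens), read by MTT assay, with a stated time of 48 h (a lower number here means a stronger inhibitor, a higher number a weaker inhibitor), compound 1 `CCn1c(C(=O)NCCN(C)C)ccc1C(CC)(CC)c1ccc(OCC(O)C(C)(C)C)c(C)c1` gives 660 nM, while compound 2 `CCn1c(C(=O)N(C)CC(=O)O)ccc1C(CC)(CC)c1ccc(OCC(O)C(C)(C)C)c(C)c1` gives 25400 nM, the higher of the two numbers. For the measured compounds named here, the only measured step, a 38-fold higher number from compound 1 to compound 2 (1.59 log units; beyond the scatter), is large. The two compounds differ in the group on the carbonyl carbon. Compound 3 `CCn1c(C(=O)Oc2ccc(CCO)cc2)ccc1C(CC)(CC)c1ccc(OCC(O)C(C)(C)C)c(C)c1` is changed at that same carbonyl carbon: a group of 10 heavy atoms (8 carbon, 2 oxygen; one six-membered aromatic ring of carbon only) in place of a group of 6 heavy atoms (3 carbon, 1 nitrogen, 2 oxygen; no ring), on a carbonyl carbon. That single step shows that this place can move the number widely, and compound 2 lies at the high end, so a lower number is expected, though by less than that step. The expected change is a 5.1-fold lower number from compound 2 to compound 3 (0.71 log units; beyond the scatter). For compound 3, the estimated value is 5000 nM, with an expected range of 900 nM to 25000 nM.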

Compound 3, half-maximal inhibitory concentration: > 50000 nM
Compound 3: a limit, no number; the forecaster's own chance of this, stated with the estimate: 10%; at least 10-fold (1.00 log units) between middle value and limit.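

In this assay compound 3 gives > 50000 nM as its reading, which is a limit of the assay and not a number. Putting the aromatic group in place of (carboxymethyl)(methyl)amino on this carbonyl carbon brings no lower number (an at least 1.9-fold higher number from compound 2 to compound 3 (0.29 log units; that floor lies within the scatter)), so the high end of this place reaches the limit or close to it. Against the dimethylamino-bearing side chain the distance is wider (an at least 75-fold higher number from compound 1 to compound 3 (1.87 log units; beyond the scatter)), and compound 1 stays the strongest of the three. Going by these compounds, how far compound 3 lies past the limit stays unknown. On these data alone, whether a piperazine or a longer aminoalkyl chain at this carbonyl carbon would bring the number down further than compound 1 also stays open.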